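The source may report more compounds than this note shows. Statements on the series, on what has been measured and on what is new or still open speak of the compounds shown alone.

Measured so far in an ADME assay on Raji cells (Homo sapiens) for cytotoxicity, read by luminescence, with a stated time of 72 h; on this read-out higher numbers stand for an effect only at larger amounts of compound and lower numbers for an effect already at smaller amounts:

- compound 1 `CCOC(=O)c1c(-c2cc(F)cc(OC)c2)[nH]c2cc(OC)ccc2c1=O`: > 21500 nM
- compound 2 `CCOC(=O)c1c(-c2cccc(Cl)c2)[nH]c2cc(OC)ccc2c1=O`: > 21500 nM

Compound 1 gives > 21500 nM in this assay, which is a limit of the assay and not a number. Compound 2 gives > 21500 nM in this assay, likewise a limit. For the measured compounds named here, compound 1 therefore stands only at a limit, and the one further value shown is a limit as well (the limit of > 21500 nM in this assay, at which 2 of the 2 values shown sit). The step that the two limits leave unreadable from compound 1 to compound 2 is accordingly unreadable in size and direction.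

Compound 3 `CCOC(=O)c1c(-c2cccc([N+](=O)[O-])c2)[nH]c2cc(OC)ccc2c1=O` differs from compound 1 in one place: 3-nitrophenyl in place of 3-fluoro-5-methoxyphenyl on an aromatic carbon. Going by the values given here, the only measured step, from compound 1 to compound 2, also exchanges one aryl group for another on the same carbon, and it sits between two limits, so it gives no size to carry over. On that basis the step that the limit leaves unreadable from compound 1 to compound 3 is expected to be none beyond the scatter, with compound 3 expected to remain at or near the limit. Compound 3 is estimated at 30000 nM, within 10000 nM to 100000 nM.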

Compound 3, half-maximal effective concentration: > 21500 nM
Compound 3 was reported as a limit; the forecaster's own chance of this, stated with the estimate: 75%; the middle value lies beyond the limit too.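

In this assay compound 3 gives > 21500 nM as a limit of the assay and not a number. No new step can be read, since compound 1, compound 2 and compound 3 all stand at a limit. The compounds shown leave open whether any of these aryl exchanges on the shared core changes the read-out, and in which direction.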